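The source may hold more compounds than are shown below. What is called first, only, known or untested is meant among the compounds shown, and "the series" means these compounds.

Compound 1, `CCCCCc1c(C)nc(N)nc1NCCCC`: 1220 nM
Compound 2, `CCCCNc1nc(N)nc(C)c1CCCN(CC)CC`: 254 nM
Compound 3, `CCCCNc1nc(N)nc(C)c1CCCCCc1ccccc1`: 830 nM

All three compounds share one core and were measured in an assay on HEK293 cells for agonist activity at Toll-like receptor 8 (Homo sapiens), read by spectrophotometry; on this read-out higher numbers stand for an effect only at larger amounts of compound and lower numbers for an effect already at smaller amounts. Among them, compound 1 stands at the highest number. Its nearest neighbour is compound 3, and the step of a 1.5-fold lower number from compound 1 to compound 3 (0.17 log units; within the scatter) lies within the scatter, so the two cannot be ordered. The step of a 4.8-fold lower number from compound 1 to compound 2 (0.68 log units; beyond the scatter) is beyond the scatter, and compound 2 therefore gives a clearly lower number than compound 1.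

Compound 4, `CCCCNc1nc(N)nc(C)c1C#C[Si](C)(C)C`, has not been measured. It differs from compound 1 in one place: a group of 6 heavy atoms (5 carbon, 1 silicon; no ring) in place of a group of 5 heavy atoms (5 carbon; no ring), on an aromatic carbon. The two measured steps from compound 1 both alter a saturated chain at this same aromatic carbon, one by introducing diethylamino and one by introducing phenyl, and they range from no change beyond the scatter to a modest gain. Neither step introduces a triple bond or a silicon atom, so they bear only loosely on the change to compound 4. Going by the values given here, with no closer precedent, the expected step of a 1.5-fold higher number from compound 1 to compound 4 (0.17 log units; within the scatter) is within the scatter, with a wide range to allow for either direction. For compound 4 the estimated value in this assay is 1800 nM, expected to fall between 500 nM and 7000 nM.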

Compound 4, half-maximal effective concentration: 9240 nM
Beside the measured number, compound 4's estimate is 5.1-fold (0.71 log units) below it, outside the stated range (above it).
By their numbers in this assay, from the lowest: compound 2; then compounds 3 and 1 (each within the scatter of the next); then compound 4.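

In this assay, going by these compounds alone, putting the silicon-bearing group with its triple bond in place of pentyl gives a 7.6-fold higher number from compound 1 to compound 4 (0.88 log units; beyond the scatter) and so marks the first change at this aromatic carbon that moves the number upward beyond the scatter. This position therefore does not take every group alike: the saturated chains of compounds 2 and 3 gave numbers lower than or level with that of compound 1, and compound 4 is the only compound shown where the chain is replaced by something other than a saturated one. Nothing measured here accounts for the rise, and the reason stays unknown.

Compound 4 brings in the triple bond and the silicon atom together, so the compounds shown leave open which of the two goes with the higher number. A triple bond carrying a tert-butyl group, with carbon where the silicon stands, or a plain propyl chain on the same aromatic carbon would help pull these two features apart.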